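A Hydroxyphenyl Takes the Place of a Bromophenyl

A few compounds are considered here, and "the series" means these few. Any claim that something is new, unique, unknown or untested is made for them only; others in the source may bear on it.

Measured compounds:
Compound 1 `COc1ccc(Nc2nc(-c3cccc(F)c3)nc3ccc(F)cc23)cc1`: 47300 nM
Compound 2 `Fc1cccc(-c2nc(Nc3cccc(Cl)c3)c3cc(F)ccc3n2)c1`: > 50000 nM (a limit of the assay)
Compound 3 `Fc1cccc(-c2nc(Nc3ccccc3Br)c3cc(F)ccc3n2)c1`: > 50000 nM (a limit of the assay)

Among the measured compounds shown here, in a functional assay on MDA-MB-231 cells (Homo sapiens) for cytotoxicity, read by MTT assay, with a stated time of 48 h (a lower number here means a stronger inhibitor, a higher number a weaker inhibitor), compound 1 gives 47300 nM, the only number in the set. Compound 2 reaches only > 50000 nM, which is a limit of the assay and not a number. Compound 3 likewise stops at > 50000 nM, again a limit. Compound 3 therefore stands at the limit of > 50000 nM in this assay, at which 2 of the 3 values shown sit, and nothing is known of it beyond that floor.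

The steps among the measured compounds carry little information: an at least 1.0-fold higher number from compound 1 to compound 2 (0.02 log units; that floor lies within the scatter), an at least 1.0-fold higher number from compound 1 to compound 3 (0.02 log units; that floor lies within the scatter), and a step that the two limits leave unreadable from compound 2 to compound 3.

Compound 4 `Oc1cccc(Nc2nc(-c3cccc(F)c3)nc3ccc(F)cc23)c1` differs from compound 3 by 3-hydroxyphenyl in place of 2-bromophenyl on a nitrogen on an aromatic ring. For the measured compounds named here, none of the measured steps touches a hydroxyphenyl, and both changes away from compound 1 ended at a limit, so the only anchor is the weak number of compound 1 and the floors of compounds 2 and 3. Compound 4 is expected to land near 40000 nM in this assay, within a broad band from 15000 nM to 100000 nM. The step of an at least 1.2-fold lower number from compound 3 to compound 4 (0.09 log units; that floor lies within the scatter) is thus estimated to be small or unreadable against the limit of compound 3.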

Compound 4, half-maximal inhibitory concentration: > 50000 nM
Compound 4 ended at the assay's limit; the forecaster's own chance of this, stated with the estimate: 45%; middle value at least 1.2-fold (0.09 log units) away from the limit.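

In this assay compound 4 stops at > 50000 nM, which is a limit of the assay. Among the compounds shown here, a 3-hydroxyphenyl on the nitrogen, with its hydrogen-bond donor and acceptor, therefore ends where the 3-chlorophenyl of compound 2 and the 2-bromophenyl of compound 3 ended, and the replacement of 2-bromophenyl brings no readable gain: the limit of > 50000 nM in this assay, at which 3 of the 4 values shown sit. The one readable step is an at least 1.0-fold higher number from compound 1 to compound 4 (0.02 log units; that floor lies within the scatter), while the steps to compound 4 from compound 2 and compound 3 cannot be read.

For the compounds shown here, compound 1 remains the only compound with a number, 47300 nM. The compounds shown do not say how far any of the other three lie past the limit. Going by these compounds, whether a phenyl bearing an amine or a carboxylic acid on this nitrogen would give a number in this assay stays open.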